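A few compounds are considered here, and "the series" means these few. Any claim that something is new, unique, unknown or untested is made for them only; others in the source may bear on it.

Measured so far in a functional assay on MCF7 cells (Homo sapiens) for inhibition, read by MTT assay, with a stated time of 72 h; on this read-out higher numbers stand for weaker inhibition and lower numbers for stronger inhibition:

- compound 1 `O=C(OC1(C(=O)Nc2ccc([N+](=O)[O-])cc2)CCCCC1)c1ccc(Br)cc1`: 237 nM
- compound 2 `O=C(OC1(C(=O)Nc2ccc([N+](=O)[O-])cc2)CCCCC1)c1ccc([N+](=O)[O-])cc1`: 8.7 nM
- compound 3 `CCOC(=O)c1ccccc1C(=O)OC1(C(=O)Nc2ccc([N+](=O)[O-])cc2)CCCCC1`: 444 nM

Among these three, compound 1 stands second highest; its nearest neighbour is compound 3, whose value sits within the scatter of it, and its furthest is compound 2, reached by a 27-fold lower number from compound 1 to compound 2 (1.44 log units; beyond the scatter) through nitro in place of bromo on an aromatic carbon. Compound 4 `CC(=O)OC1(C(=O)Nc2ccc([N+](=O)[O-])cc2)CCCCC1` is not yet measured. It arises from compound 1 by methyl in place of 4-bromophenyl on a carbonyl carbon, that is, (4-bromophenyl)carbonyl to acetyl. For the measured compounds named here, no measured step changes this part of the molecule: the one large step, from compound 1 to compound 2, alters a substituent on the aromatic ring that compound 4 no longer carries, and compound 3 only shows that a different aryl ester gives a value within the scatter of compound 1. Going by the values given here, the only guide is that the aryl portion clearly matters in that step, so its loss is expected to weaken inhibition. For compound 4 the expected result in this assay is 1200 nM, with a range of 250 nM to 6000 nM, a step of a 5.1-fold higher number from compound 1 to compound 4 (0.70 log units; beyond the scatter) that is expected but uncertain.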

Compound 4, half-maximal inhibitory concentration: 403 nM
For compound 4 the middle estimate is 3.0-fold (0.47 log units) above the measured one; the range from low to high includes it.
By their numbers in this assay, from the lowest: compound 2; then compounds 1, 4 and 3 (each within the scatter of the next).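

In this assay, replacing the 4-bromophenyl on the carbonyl carbon with methyl keeps the number within the scatter (a 1.7-fold higher number from compound 1 to compound 4 (0.23 log units; within the scatter)), so a 4-bromophenyl ring at this position gives no measurable gain over a single carbon. The same replacement of 4-nitrophenyl has a large effect (a 46-fold higher number from compound 2 to compound 4 (1.67 log units; beyond the scatter)), which shows that the strong inhibition is tied to that particular group and not to the mere presence of an aromatic ring here. Nothing available explains why these two aromatic groups behave so differently.

Going by these compounds, it remains open whether another ring substituent, such as a nitrile or a carboxylic acid, could match the nitro group. On these data alone, it is equally open whether a longer chain or an amine in place of methyl would move the number at all.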